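The source may hold more compounds than are shown below. What is called first, only, known or untested is meant among the compounds shown, and "the series" means these compounds.

Working notes on the series. Compound 1 `c1ccc2c(c1)CCC2NC1CCN(CCCc2c[nH]c3ccc(-n4cnnc4)cc23)CC1` gives 25 nM in an assay on CHO cells for agonist activity at 5-hydroxytryptamine receptor 1D (Homo sapiens), read by GTPgammaS binding; on this read-out lower numbers stand for an effect already at smaller amounts and higher numbers for an effect only at larger amounts of compound. Compound 2 `COC[C@H](NC1CCN(CCCc2c[nH]c3ccc(-n4cnnc4)cc23)CC1)c1ccccc1` gives 0.9 nM in that assay, and compound 3 `c1cc(CNC2CCN(CCCc3c[nH]c4ccc(-n5cnnc5)cc34)CC2)co1` gives 7.1 nM. On these three numbers compound 3 stands second highest: above it only compound 1, with a 3.5-fold lower number from compound 1 to compound 3 (0.55 log units; beyond the scatter) separating them, and below it compound 2, with a 7.9-fold higher number from compound 2 to compound 3 (0.90 log units; beyond the scatter) between them. The change now followed is 1-phenylethyl in place of (furan-3-yl)methyl on an amine nitrogen, giving compound 4 `C[C@H](NC1CCN(CCCc2c[nH]c3ccc(-n4cnnc4)cc23)CC1)c1ccccc1`. Among the compounds with values here, the steps that bear on it are the two through compound 3, in particular a 7.9-fold higher number from compound 2 to compound 3 (0.90 log units; beyond the scatter), since the 2-methoxy-1-phenylethyl group of compound 2 and the 1-phenylethyl group entering in compound 4 share the phenyl-bearing stereocentre on the amine nitrogen and differ only in the methoxymethyl part. The other phenyl-free groups, 2,3-dihydro-1H-inden-1-yl and (furan-3-yl)methyl, both gave higher numbers than compound 2. A step of modest size toward a lower number is therefore expected, a 4.7-fold lower number from compound 3 to compound 4 (0.68 log units; beyond the scatter), bringing compound 4 near compound 2. Compound 4 is estimated at 1.5 nM, with a range of 0.5 nM to 5 nM.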

Compound 4, half-maximal effective concentration: 12 nM
The estimate for compound 4 lay 8.0-fold (0.90 log units) below the measured number, outside the stated range (above it).
By their numbers in this assay, from the lowest: compound 2; then compounds 3 and 4 (each within the scatter of the next); then compound 1.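

In this assay, the methoxy group on the chain carbon carries most of the low number of compound 2: a 13-fold higher number from compound 2 to compound 4 (1.12 log units; beyond the scatter) is a large step for that single replacement, so the phenyl-bearing stereocentre alone does not reproduce it. At the amine nitrogen, 1-phenylethyl and (furan-3-yl)methyl cannot be told apart, with a 1.7-fold higher number from compound 3 to compound 4 (0.23 log units; within the scatter) lying within the scatter, while a 2.1-fold lower number from compound 1 to compound 4 (0.32 log units; beyond the scatter) is a modest step away from 2,3-dihydro-1H-inden-1-yl. Nothing available explains why the methoxy group makes this difference.

The compounds shown leave open whether a hydroxy or an ethoxy group on that chain carbon would keep the number of compound 2. They also leave open how the opposite arrangement at the stereocentre would read.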